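The source may hold more compounds than are shown below. What is called first, only, known or untested is meant among the compounds shown, and "the series" means these compounds.

Of the compounds shown here, two have been measured in a functional assay on the whole organism (B cells) with Mus musculus as the target; on this read-out higher numbers stand for larger maximal responses and lower numbers for smaller maximal responses. Compound 1 `Nc1nc(O)c2c(n1)n(C1OC(CO)[C@@H](O)[C@H]1O)c(=O)n2CC(O)CSc1ccccc1` gives 12% in this assay, the lower of the two numbers at hand. Compound 2 `CCCn1c(=O)n(C2CCC(CO)O2)c2nc(NC(=O)C(C)(C)C)nc(O)c21` gives 19% in this assay, a number that lies above that of compound 1 only by an amount within the scatter, so the two stand together. Among the compounds with values here, no pair of measured compounds differs in a single place, so no step from one measured compound to another is available as a guide.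

Compound 3 `Nc1nc(O)c2c(n1)n(C1OC(CO)[C@@H](O)[C@H]1O)c(=O)n2Cc1ccc(Cl)c(Cl)c1` has not yet been measured in this assay. It differs from compound 1 in one place: 3,4-dichlorophenyl in place of 1-hydroxy-2-(phenylsulfanyl)ethyl on a saturated chain carbon bound to an aromatic nitrogen. The 1-hydroxy-2-(phenylsulfanyl)ethyl of compound 1 leaves and a 3,4-dichlorophenyl enters on the saturated chain carbon bound to the aromatic nitrogen. Within the data shown here, nothing measured so far shows how this assay answers such a change, so the expectation rests on compound 1 and its 12%. Compound 3 is expected to give about 20% in this assay, within a range from 5% to 45%. The expected step of a number 8 percentage points higher from compound 1 to compound 3 (within the scatter) is no larger than the scatter.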

Compound 3, largest response reached (reported as maximal response), in percent of the reference or control that the assay uses: 55%
For compound 3 the middle estimate is 35 percentage points below the measured one; the measured number lies above the stated range.
By their numbers in this assay, from the lowest: compounds 1 and 2 (each within the scatter of the next); then compound 3.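

Within the data shown here, the saturated chain carbon bound to an aromatic nitrogen proves to be a place where this assay responds strongly: with the rest of the structure unchanged, 3,4-dichlorophenyl in place of 1-hydroxy-2-(phenylsulfanyl)ethyl gives a number 43 percentage points higher from compound 1 to compound 3 (beyond the scatter), and this is the first single-place step available. The exchange alters several things at once, since the leaving group carries one hydrogen-bond donor, two hydrogen-bond acceptors and a sulfur atom, while the entering group has no donors or acceptors and brings two chlorine atoms, so this one step cannot assign the gain to any one of these differences. Nothing at hand explains why the response rises at this place.

The compounds shown leave open whether the two chlorine atoms are needed at all, which a plain phenyl or a 4-chlorophenyl at the same place would help to settle. They also leave open what the hydroxyl and the sulfur contribute on the side of compound 1, a question that a 2-(phenylsulfanyl)ethyl without the hydroxyl or a simple butyl chain could address.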